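Dichlorobenzyl replacement in the bis(trifluoromethyl)sulfonamide series

The source may report more compounds than this note shows. Statements on the series, on what has been measured and on what is new or still open speak of the compounds shown alone.

The series shares a bis(trifluoromethyl)benzenesulfonamide core carrying an aminoalkyl chain capped by an arylmethyl group. In a functional assay on HT-29 cells (Homo sapiens) for inhibition, read by MTT assay, with a stated time of 72 h (on this read-out higher numbers stand for weaker inhibition of growth and lower numbers for stronger inhibition of growth), compound 1 `O=S(=O)(NCCNCc1cccc2ccccc12)c1cc(C(F)(F)F)cc(C(F)(F)F)c1` gives 16000 nM. Compound 3 `O=S(=O)(NCCNCc1ccc(-c2ccccc2)cc1)c1cc(C(F)(F)F)cc(C(F)(F)F)c1` gives 2700 nM in this assay. Compound 2 `CC(C)(C)c1ccc(CNCCCNS(=O)(=O)c2cc(C(F)(F)F)cc(C(F)(F)F)c2)cc1` gives 2000 nM in this assay, the lowest number of the three; compound 3 lies within the scatter of it, while compound 1 sits well beyond. For the measured compounds named here, compounds 1 and 3 differ from compound 2 in more than one place, so no single step between measured compounds can be read from them.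

Compound 4 `O=S(=O)(NCCCNCc1ccc(Cl)c(Cl)c1)c1cc(C(F)(F)F)cc(C(F)(F)F)c1` has not been measured in this assay. It differs from compound 2 by one change: 3,4-dichlorophenyl in place of 4-(tert-butyl)phenyl on a saturated chain carbon bound to an amine nitrogen. Going by the values given here, nothing among the measured compounds probes a change of this kind, so the step from compound 2 to compound 4 is open. Both groups are uncharged six-membered carbon rings without donors or acceptors, and the expected step of a 1.5-fold higher number from compound 2 to compound 4 (0.18 log units; within the scatter) is a small one, not beyond the scatter, with a slight lean towards a higher number. Compound 4 is therefore estimated at 3000 nM in this assay, with a range from 1000 nM to 10000 nM.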

Compound 4, concentration for 50% growth inhibition: 4700 nM
Beside the measured number, compound 4's estimate is 1.6-fold (0.19 log units) below it; the measured number falls inside the stated range.
By their numbers in this assay, from the lowest: compounds 2, 3 and 4 (each within the scatter of the next, the first and the last beyond it); then compound 1.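

In this assay, 3,4-dichlorophenyl in place of 4-(tert-butyl)phenyl on a saturated chain carbon bound to an amine nitrogen gives a 2.4-fold higher number from compound 2 to compound 4 (0.37 log units; beyond the scatter). For the compounds shown here, this is the first single-place step, and it shows that this position is sensitive to the identity of the aryl group, modestly but beyond the scatter, even though both groups are uncharged six-membered carbon rings with no hydrogen-bond donors or acceptors. Nothing available accounts for the step, which stands as an observation on this one pair.

The steps from compound 1 and compound 3 to the other compounds cannot be read, as each differs in more than one place, so the contribution of the chain and the effect of the larger aryl caps remain unseparated. Also open, on these data alone, is how this position would respond to a monochlorophenyl group, a methoxyphenyl group or a pyridine ring, which would show whether the step belongs to the loss of the tert-butyl group or to the arrival of the chlorines.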